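The compounds below may be only part of what the source reports. "The series", "measured", "known", "first", "only" and "open" are said of these compounds alone.

Measured in a functional assay on A549 cells (Homo sapiens) for inhibition, read by CCK-8 assay, with a stated time of 72 h, tested at 2 uM; a lower number here means less inhibition of growth, a higher number more inhibition of growth at the concentration tested:
- compound 1 `Nc1ccccc1NC(=O)/C=C/c1ccc(CSc2ccc(Cl)cc2)cc1`: 55.3%
- compound 2 `Nc1ccccc1NC(=O)/C=C/c1ccc(CSc2cccc(F)c2)cc1`: 50.7%
- compound 3 `CCc1ccc(SCc2ccc(/C=C/C(=O)Nc3ccccc3N)cc2)cc1`: 60.7%

Compound 3 carries a 4-ethylphenyl group on the sulfur and does not separate from the other two compounds. The values show a number 5.4 percentage points higher from compound 1 to compound 3 (within the scatter) and a number 10 percentage points higher from compound 2 to compound 3 (within the scatter), and both steps lie within the scatter. The remaining pair gives a number 4.6 percentage points lower from compound 1 to compound 2 (within the scatter), also within the scatter.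

Compound 4 `Cc1ccc(SCc2ccc(/C=C/C(=O)Nc3ccccc3N)cc2)cc1` differs from compound 3 by one small change: hydrogen in place of methyl on a saturated chain carbon bound to an aromatic carbon. This is hydrogen in place of methyl on a saturated chain carbon bound to an aromatic carbon, so ethyl becomes methyl and 4-ethylphenyl becomes 4-methylphenyl.

Going by the values given here, no measured step makes this exact change. The three steps above are the nearest evidence, since each alters the aromatic group on the sulfur, and even the exchanges of chloro, fluoro and ethyl stayed within the scatter. From the compounds shown here alone, on that basis, no step beyond the scatter is expected in this assay, and the direction remains open, with only a slight drop assumed. The expected change is a number 3.7 percentage points lower from compound 3 to compound 4 (within the scatter). For compound 4 the estimated value is 57%, with an expected range of 46% to 68%.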

Compound 4, percent growth inhibition at one concentration: 43.4%
Beside the measured number, compound 4's estimate is 13.6 percentage points above it; the whole stated range lies above it.
By their numbers in this assay, from the lowest: compounds 4, 2, 1 and 3 (each within the scatter of the next, the first and the last beyond it).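

Within this assay, shortening ethyl to methyl on this saturated chain carbon bound to an aromatic carbon gives a number 17.3 percentage points lower from compound 3 to compound 4 (beyond the scatter) even though only one carbon leaves, whereas the earlier exchanges among chloro, fluoro and ethyl all stayed inside the scatter. The 4-methylphenyl group on the sulfur also gives a number 11.9 percentage points lower from compound 1 to compound 4 (beyond the scatter) while the comparison with the 3-fluorophenyl group gives a number 7.3 percentage points lower from compound 2 to compound 4 (within the scatter) so compound 4 separates from compound 3 and compound 1 but not from compound 2, and the series therefore responds to a small change in this aromatic group more than the first three values suggested. Nothing available bears on why removing this single carbon matters.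

Still open, from the compounds shown here alone, is whether the read-out tracks chain length at this place, which a propyl group or a longer chain would test, or whether ethyl is a singular case among small groups. A hydroxymethyl group or an aminomethyl group in the same place would show whether a chain carrying oxygen or nitrogen keeps the level of compound 3 or falls toward that of compound 4.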